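Amino in Place of Methylsulfanyl on a Second Core

The compounds below may be only part of what the source reports. "The series", "measured", "known", "first", "only" and "open" are said of these compounds alone.

Compound 1 `COc1ccc2c(/C=C/C(=O)c3cc(OC)c(OC)c(SC)c3)c[nH]c2c1` and compound 2 `COc1ccc2c(/C=C/C(=O)c3cc(N)c(OC)c(OC)c3)c[nH]c2c1` share one core, while compound 3 `COc1cc(C(=O)/C=C/c2cn(C)c3ccccc23)cc(SC)c1OC` and compound 4 `COc1cc(C(=O)/C=C/c2cn(C)c3ccccc23)cc(N)c1OC` share another; the difference between the two cores is not broken down here. In a functional assay on MCF7 cells (Homo sapiens) for antiproliferative activity, read by MTT assay, with a stated time of 48 h (on this read-out higher numbers stand for weaker inhibition and lower numbers for stronger inhibition), compound 1 gives 101 nM, and compound 2 gives 249 nM. The change between them, (amino in place of methylsulfanyl on an aromatic carbon), produced a 2.5-fold higher number from compound 1 to compound 2 (0.39 log units; beyond the scatter). In this assay compound 3 gives 102 nM, which lies within the scatter of compound 1.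

The same change is now carried onto the core of compound 3 to give compound 4: amino in place of methylsulfanyl on an aromatic carbon. The surroundings of the place are described in the same words for both pairs, so this is taken as the same change. The expected step of a 2.5-fold higher number from compound 3 to compound 4 (0.39 log units; beyond the scatter) is set beside the measured step of a 2.5-fold higher number from compound 1 to compound 2 (0.39 log units; beyond the scatter), and it rests on that single earlier step together with the level at which compound 3 sits, 102 nM, which lies within the scatter of compound 1. Going by the values given here, with only one precedent, the range is kept wide. Compound 4 is therefore estimated at 250 nM in this assay. Compound 4 is expected to fall between 120 nM and 520 nM.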

Compound 4, half-maximal inhibitory concentration: 631 nM
Beside the measured number, compound 4's estimate is 2.5-fold (0.40 log units) below it; measured number above the stated range.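

Carried onto the core of compound 3, amino in place of methylsulfanyl on an aromatic carbon gave a 6.2-fold higher number from compound 3 to compound 4 (0.79 log units; beyond the scatter) in this assay, the same direction as on the core of compound 1. Set side by side, the two steps cannot be told apart: the same change on two cores in this assay, a 2.5-fold higher number (0.39 log units; beyond the scatter) from compound 1 to compound 2 and a 6.2-fold higher number (0.79 log units; beyond the scatter) from compound 3 to compound 4, 2.5-fold (0.40 log units) apart, within the scatter of two such steps. This supports carrying the direction of the change between these two cores, but it does not show that the change acts more strongly on one core than on the other, and two pairs set no rule for any core beyond those of compound 1 and compound 3.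

What the compounds shown leave open is whether a hydroxyl group or an ethylsulfanyl group on the same aromatic carbon would give numbers closer to those of the methylsulfanyl compounds or the amino compounds. They also leave open which part of the difference between the two cores, if any, bears on the size of the step.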